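A few compounds are considered here, and "the series" means these few. Any claim that something is new, unique, unknown or untested is made for them only; others in the source may bear on it.

Measured so far:
compound 1, `CNc1c(C(N)=O)sc2ccccc12` — 34000 nM
compound 2, `NNC(=O)c1sc2ncccc2c1N` — a limit
compound 3, `Cc1ccnc2sc(C(N)=O)c(N)c12` — 11000 nM

In an assay on isolated protein for inhibition of LIM domain kinase 1 (Homo sapiens), read by Kinase-Glo, with a stated time of 60 min (a lower number here means a stronger inhibitor, a higher number a weaker inhibitor), compound 1 gives 34000 nM. Compound 2 reaches only the assay's limit at > 100000 nM; this is a limit, not a number, and it is the point noted as the limit of > 100000 nM in this assay, at which 1 of the 3 values shown sits. Compound 3 gives 11000 nM. Among the two numbers, compound 1 stands highest, and compound 3, its nearest neighbour, sits beyond the usual scatter below it. Compound 4, `NC(=O)c1sc2ccccc2c1N`, differs from compound 1 by hydrogen in place of methyl on a nitrogen on an aromatic ring. Among the compounds with values here, no step between measured compounds exists here, so only a modest step in this assay is expected, somewhat toward a lower number. For compound 4 an expected value of 20000 nM is estimated, spanning 7000 nM to 60000 nM, which means a step of a 1.7-fold lower number from compound 1 to compound 4 (0.23 log units; within the scatter).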

Compound 4, half-maximal inhibitory concentration: 33000 nM
Compound 4: middle estimate off by 1.7-fold (0.22 log units), on the low side, and the stated range covers the measured number.
By their numbers in this assay, from the lowest: compound 3; then compounds 4 and 1 (each within the scatter of the next). At a limit, above all of these: compound 2.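

In this assay, exchanging methylamino for amino on the shared core gives a 1.0-fold lower number from compound 1 to compound 4 (0.01 log units; within the scatter), so this change leaves the reading within the scatter. At this nitrogen on the aromatic ring, then, the methyl is neither required for nor an obstacle to the weak inhibition seen here. Nothing on record bears on why the two compounds read alike.

The compounds shown leave open whether an acetyl group or a longer chain such as propyl on this nitrogen would also read alike. They also leave open whether the same exchange would behave this way on the core of compound 3.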